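The source may report more compounds than this note shows. Statements on the series, on what has been measured and on what is new or still open speak of the compounds shown alone.

Among the compounds with values here, in a functional assay on DU-145 cells (Homo sapiens) for cytotoxicity, read by sulforhodamine B assay, with a stated time of 3 days (on this read-out lower numbers stand for an effect already at smaller amounts and higher numbers for an effect only at larger amounts of compound), three compounds that all carry a carboxy group have numbers so far. Compound 1 `Cc1coc(-c2ccc3c(c2O)CCCC3(C)C)c1C(=O)O` gives 3 uM, compound 2 `COc1c(-c2occ(C)c2C(=O)O)ccc2c1CCCC2(C)C` gives 34.1 uM and compound 3 `CCc1cccc2c(O)c(-c3occ(C)c3C(=O)O)ccc12` gives 29.4 uM. Compound 2 therefore stands at the high end of these numbers, together with compound 3 and within the scatter of it, while compound 1 lies well apart at a lower number.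

Within the data shown here, the only measured step is an 11-fold higher number from compound 1 to compound 2 (1.06 log units; beyond the scatter), with methyl in place of hydrogen on an oxygen on an aromatic ring. Compound 4 `COCc1c(C)coc1-c1ccc2c(c1OC)CCCC2(C)C` keeps that methyl and changes another place: methoxymethyl in place of carboxy on an aromatic carbon. Among the measured compounds shown here, the measured step shows that one small change can move this number beyond the scatter, but it says nothing about this exchange, and no measured compound lacks the carboxy group. As far as these compounds go, the direction therefore stays open, and the expectation starts from compound 2 at 34.1 uM. No shift beyond the scatter is expected, and the estimated step is a 1.1-fold lower number from compound 2 to compound 4 (0.06 log units; within the scatter). For compound 4 the estimated value is 30 uM, within an expected range from 8 uM to 100 uM.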

Compound 4, concentration for half-maximal effect: 17.5 uM
Compound 4: the middle estimate sits 1.7-fold (0.23 log units) above what was measured; measured number inside the range.
By their numbers in this assay, from the lowest: compound 1; then compounds 4, 3 and 2 (each within the scatter of the next).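

In this assay the exchange of carboxy for methoxymethyl on an aromatic carbon of the five-membered aromatic ring gives a 1.9-fold lower number from compound 2 to compound 4 (0.29 log units; within the scatter) and thus shows that, with the methyl on the oxygen kept, this place takes a group other than carboxy without a shift beyond the scatter. Compound 4 is the first compound here without a carboxy group, and the hydrogen-bond donor that carboxy counts and methoxymethyl lacks is therefore not required for a number in the range of compound 2, while the step from the free hydroxy to the methyl ether remains the only one shown that goes beyond the scatter. No measurement shown here gives a reason for this result.

As far as these compounds go, it stays open whether the same exchange would also leave the number within the scatter with hydrogen on the oxygen, as in compound 1, which holds the lowest number here. From the compounds shown here alone, what a hydroxymethyl, a primary amide or an aminomethyl group would give at this place also stays open, and so does whether a longer ether chain would behave like methoxymethyl.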